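This account rests on a few compounds, and the source may have more. Where it says the series, first, only, none or still open, it means among the compounds named here.

Going by the values given here, compound 1, with the structure `C=C/C=C\[C@H](C)[C@H](OC(N)=O)[C@@H](C)[C@H](O)[C@@H](C)C/C(C)=C\[C@H](C)[C@@H](O)[C@@H](C)/C=C\CCc1ccc(C)c(F)c1`, is the weaker of the two compounds measured so far in a functional assay on MCF7 cells (Homo sapiens) for cytotoxicity; on this read-out lower numbers stand for stronger inhibition and higher numbers for weaker inhibition: compound 1 gives 4000 nM, the highest of the two numbers. Among the compounds with values here, its nearest neighbour is compound 2, `C=C/C=C\[C@H](C)[C@H](OC(N)=O)[C@@H](C)[C@H](O)[C@@H](C)C/C(C)=C\[C@H](C)[C@@H](O)[C@@H](C)/C=C\CCc1ccccc1`, which in this assay gives 560 nM, and the only measured step, a 7.1-fold lower number from compound 1 to compound 2 (0.85 log units; beyond the scatter), came from putting phenyl in place of 3-fluoro-4-methylphenyl on a saturated chain carbon, two bonds along the chain from a double-bonded chain carbon.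

Compound 3, `C=C/C=C\[C@H](C)[C@H](OC(N)=O)[C@@H](C)[C@H](O)[C@@H](C)C/C(C)=C\[C@H](C)[C@@H](O)[C@@H](C)/C=C\CCc1cccc(O)c1`, has not yet been measured. It differs from compound 1 at the same spot: 3-hydroxyphenyl in place of 3-fluoro-4-methylphenyl on a saturated chain carbon, two bonds along the chain from a double-bonded chain carbon. Within the data shown here, the one measured step bears on this, since it also removed the 3-fluoro-4-methylphenyl group from that position and gave a clearly lower number. Because of a 7.1-fold lower number from compound 1 to compound 2 (0.85 log units; beyond the scatter), the expected outcome for compound 3 in this assay is a lower number than for compound 1, in the same direction and of roughly similar size, though the entering 3-hydroxyphenyl is not the phenyl of compound 2, so the expected step of a 5.0-fold lower number from compound 1 to compound 3 (0.70 log units; beyond the scatter) is set with a wide margin. The estimate for compound 3 is therefore 800 nM, expected to lie between 200 nM and 3200 nM.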

Compound 3, half-maximal inhibitory concentration: 390 nM
Estimate against measurement, compound 3: 2.1-fold (0.31 log units) above, within the range that was stated.
By their numbers in this assay, from the lowest: compounds 3 and 2 (each within the scatter of the next); then compound 1.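

In this assay, the step with 3-hydroxyphenyl in place of 3-fluoro-4-methylphenyl is a 10-fold lower number from compound 1 to compound 3 (1.01 log units; beyond the scatter) and so shows that a second, different group at this position, on a saturated chain carbon, also gives a number well under that of compound 1; the earlier result with plain phenyl is therefore not a lone case. Hydroxy in place of hydrogen on an aromatic carbon gives a 1.4-fold lower number from compound 2 to compound 3 (0.16 log units; within the scatter) and leaves the two compounds indistinguishable in this assay, so a ring hydroxy group at this spot neither adds to nor takes away from what plain phenyl gives, as far as this read-out can tell. Nothing available explains why the 3-fluoro-4-methylphenyl compound stands apart from the other two.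

On these data alone, what remains open is whether the fluorine, the methyl or only the two together go with the higher number, which a phenyl ring carrying just a fluorine or just a methyl would separate. As far as these compounds go, it is also open how an amine or a methoxy group in place of the hydroxy, or a longer chain leading to the ring, would fare at this position.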